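The compounds below may be only part of what the source reports. "The series", "measured", "known", "first", "only" and "open" are said of these compounds alone.

Measured compounds, all in a functional assay on SK-OV-3 cells (Homo sapiens) for cytotoxicity, read by MTT assay, with a stated time of 3 days; a lower number here means a stronger inhibitor, a higher number a weaker inhibitor 
- compound 1 `N#Cc1c(NN)nc(SCc2nc3ccccc3[nH]2)nc1-c1ccccc1` gives 2.7 nM 
- compound 2 `CCNc1nc(SCc2nc3ccccc3[nH]2)nc(-c2ccccc2)c1C#N` gives 7.35 nM 

Compound 2 at 7.35 nM holds the higher of the two numbers, which makes it the weaker of the pair so far. Compound 3 `N#Cc1c(NNC(N)=S)nc(SCc2nc3ccccc3[nH]2)nc1-c1ccccc1` has not yet been measured. The change from compound 2 to compound 3 is a group of 4 heavy atoms (1 carbon, 2 nitrogen, 1 sulfur; no ring) in place of a group of 2 heavy atoms (2 carbon; no ring), on a nitrogen on an aromatic ring on a nitrogen on an aromatic ring. Going by the values given here, the only measured step at that place is a 2.7-fold higher number from compound 1 to compound 2 (0.43 log units; beyond the scatter) and it is modest, so a small move toward a lower number is expected in this assay on leaving ethyl. Among the compounds with values here, no measurement yet covers the entering group, which keeps this expectation loose. The estimated change is a 1.5-fold lower number from compound 2 to compound 3 (0.17 log units; within the scatter) and is expected to stay within the scatter. For compound 3 the expected value is 5 nM with an estimated range from 1.5 nM to 20 nM on current evidence.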

Compound 3, half-maximal inhibitory concentration: 3 nM
The estimate for compound 3 lay 1.7-fold (0.22 log units) above the measured number; low and high end bracket the measured number.
By their numbers in this assay, from the lowest: compounds 1 and 3 (each within the scatter of the next); then compound 2.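

In this assay, the position on a nitrogen on an aromatic ring takes a group of 4 heavy atoms (1 carbon, 2 nitrogen, 1 sulfur; no ring) without any loss against ethyl, with a 2.5-fold lower number from compound 2 to compound 3 (0.39 log units; beyond the scatter) as the step on that exchange, so a larger group here does not by itself go with a higher number among these three compounds. Replacing a hydrogen atom on the amine nitrogen gives a 1.1-fold higher number from compound 1 to compound 3 (0.05 log units; within the scatter) as its step, which leaves the pair inseparable and sets ethyl apart as the only one of the three substituents with a number beyond the scatter of the others. No measured property is available to explain either step.

As far as these compounds go, how a longer chain such as butyl, or a phenyl ring, would stand on this nitrogen remains open, and with it whether the reading for ethyl reflects a trend or a single case. Also open, from the compounds shown here alone, is whether the sulfur of the entering group matters, which an oxygen in its place would test.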